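Swapping the amide ring of compound 1 for phenyl

The source may hold more compounds than are shown below. What is called first, only, known or untested is meant among the compounds shown, and "the series" means these compounds.

Compound 1 `O=C(Nc1ccccn1)c1c(O)c2cccnc2n(-c2ccccc2)c1=O` stands higher of the two compounds measured in a functional assay on the whole organism for inhibition, with Rattus norvegicus as the target, read by cytopathic effect and paw edema, at a dose of 100 mg/kg by the oral route; a higher number here means more inhibition at the dose given (going by the name of the read-out), a lower number less inhibition: compound 1 gives 14.6% there, while compound 2 `O=C(NN1CCOCC1)c1c(O)c2cccnc2n(-c2ccccc2)c1=O` gives -26.2% in this assay. For the measured compounds named here, the single measured step, a number 40.8 percentage points lower from compound 1 to compound 2 (beyond the scatter), shows how strongly a change at this amide nitrogen can move the read-out. Compound 3 `O=C(Nc1ccccc1)c1c(O)c2cccnc2n(-c2ccccc2)c1=O` differs from compound 1 by phenyl in place of pyridin-2-yl on an amide-type nitrogen. Going by the values given here, no measured step covers phenyl against pyridin-2-yl, so that step is only a loose guide. A small fall within the scatter is expected as the step of a number 6.6 percentage points lower from compound 1 to compound 3 (within the scatter). Compound 3 is therefore estimated at 8%, within -20% to 30%.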

Compound 3, a percentage reported as inhibition, in the whole organism at one dose (the size of the read-out at that dose, not a potency): -15%
The estimate for compound 3 lay 23 percentage points above the measured number; low and high end bracket the measured number.
By their numbers in this assay, from the lowest: compound 2; then compound 3; then compound 1.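

Phenyl and pyridin-2-yl are both six-membered aromatic rings, yet the swap on the amide-type nitrogen gives a number 29.6 percentage points lower from compound 1 to compound 3 (beyond the scatter) in this assay, so within this pair the higher number goes with the ring that carries a nitrogen. With a number 11.2 percentage points higher from compound 2 to compound 3 (beyond the scatter) as well, phenyl sits between the other two groups, so an aromatic ring alone does not set the number here. For the compounds shown here, nothing measured so far explains these steps. Still open, as far as these compounds go, is whether the place of the ring nitrogen matters, which a pyridin-3-yl group could test. A benzyl group on the same nitrogen would show what a carbon spacer before the ring does.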